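The compounds below may be only part of what the source reports. "The series", "measured", "known", "first", "only" and "open" are said of these compounds alone.

Compound 1 `Cc1cc(N(C)C)nc(NCc2ccccc2)n1`, compound 2 `Cc1cc(N(C)C)nc(N[C@H](C)c2ccccc2)n1` and compound 3 `Cc1cc(N(C)C)nc(NCc2ccc(Cl)cc2)n1` have been tested in an ADME assay on Vero cells (Chlorocebus sabaeus) for cytotoxicity; on this read-out lower numbers stand for an effect already at smaller amounts and higher numbers for an effect only at larger amounts of compound. In this assay compound 1 gives > 50100 nM, which is a limit of the assay and not a number. Compound 2 gives > 50100 nM, again a limit. Compound 3 gives 25100 nM. Compound 1 thus stands at a limit, and the limit of > 50100 nM in this assay, at which 2 of the 3 values shown sit, shows that compound 2 sits at that same limit.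

Compound 4 `Cc1cc(N(C)C)nc(NCC2CCOCC2)n1` has not yet been tested. It differs from compound 1 in one place: oxan-4-yl in place of phenyl on a saturated chain carbon bound to a nitrogen on an aromatic ring.

Two measured steps start from compound 1. The step that the two limits leave unreadable from compound 1 to compound 2 touches the saturated chain carbon on which compound 4 also differs, and both its ends are limits, so its size cannot be read. The step of an at least 1.9-fold lower number from compound 1 to compound 3 (0.30 log units; that floor lies within the scatter) touches the phenyl that compound 4 no longer carries; its floor lies within the scatter, so it does not show a clear move. Neither step points to a shift beyond the scatter for compound 4. The expectation in this assay is therefore a step that the limit leaves unreadable from compound 1 to compound 4, with a good chance that only a limit is reported again. Compound 4 is estimated at 60000 nM, with a range from 25000 nM to 150000 nM.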

Compound 4, half-maximal effective concentration: > 50100 nM
Compound 4 was reported as a limit; the forecaster's own chance of this, stated with the estimate: 75%; the middle value lies beyond the limit too.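

In this assay compound 4 gives > 50100 nM, which is a limit of the assay and not a number. Compound 1 also stands at a limit, so no size can be read for the change between compound 1 and compound 4. The compounds shown leave open whether oxan-4-yl in place of phenyl changes the result in this assay at all.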